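A few compounds are considered here, and "the series" means these few. Any claim that something is new, unique, unknown or untested is made for them only; others in the source may bear on it.

Measured in a functional assay on A549 cells (Homo sapiens) for antiproliferative activity, read by MTT assay, with a stated time of 48 h; a higher number here means a weaker inhibitor, a lower number a stronger inhibitor:
Compound 1 `c1ccc(-c2nn(-c3ccccc3)cc2-c2nc3ccccc3[nH]2)cc1` gives 2710 nM
Compound 2 `Clc1ccc(-c2nn(-c3ccccc3)cc2-c2nc3ccccc3[nH]2)cc1` gives 5960 nM

Compound 2 holds the higher of the two numbers, which makes it the weaker inhibitor of the pair in this assay. Compound 3 `O=C(OCc1ccccc1)c1ccc2[nH]c(-c3cn(-c4ccccc4)nc3-c3ccc(Cl)cc3)nc2c1` departs from compound 2 through (benzyloxycarbonyl in place of hydrogen on an aromatic carbon). This is benzyloxycarbonyl in place of hydrogen on an aromatic carbon, on a six-membered aromatic ring of carbon only that is part of a fused or bridged system of two rings.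

Within the data shown here, only one measured step exists, and it is modest: a 2.2-fold higher number from compound 1 to compound 2 (0.34 log units; beyond the scatter). That step is a chloro in place of hydrogen on an aromatic carbon, a much smaller change than the one at issue, so it is a weak guide to size and gives no direction. Among the measured compounds shown here, no measured compound carries benzyloxycarbonyl. The best expectation in this assay is therefore no step beyond the scatter, with real uncertainty in either direction. The expected step is a 1.3-fold lower number from compound 2 to compound 3 (0.12 log units; within the scatter). Compound 3 is estimated at 4500 nM, with an expected range from 1300 nM to 15000 nM.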

Compound 3, half-maximal inhibitory concentration: 7730 nM
The estimate for compound 3 lay 1.7-fold (0.23 log units) below the measured number, and the stated range covers the measured number.
By their numbers in this assay, from the lowest: compound 1; then compounds 2 and 3 (each within the scatter of the next).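

In this assay, the step of benzyloxycarbonyl in place of hydrogen on an aromatic carbon of the six-membered aromatic ring of carbon only, part of a fused system of two rings, is a 1.3-fold higher number from compound 2 to compound 3 (0.11 log units; within the scatter), so this position takes a group of 10 heavy atoms, including a further six-membered aromatic ring, with no change in the number beyond the scatter. The earlier compounds shown here showed only a chloro in place of hydrogen at a different place, where the step was a 2.2-fold higher number from compound 1 to compound 2 (0.34 log units; beyond the scatter), and they said nothing about this ring of the core or about a group of this size. Nothing measured bears on what lies behind this result.

The compounds shown leave open whether a carboxylic acid or an amine on the same aromatic carbon would also stay within the scatter of compound 2 or would move the number beyond it. They also leave open whether benzyloxycarbonyl would behave the same way on the core of compound 1, which carries hydrogen in place of the chloro.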